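Nitro to cyano on the benzoyl arm: cytotoxicity estimate

The compounds below may be only part of what the source reports. "The series", "measured", "known", "first", "only" and "open" are said of these compounds alone.

Compound 1 `O=C(NC(=S)N1CCc2c(OCCCCCOc3ccc(Cl)cc3)cccc21)Oc1ccccc1` sits at a limit in an ADME assay on Huh-7 cells (Homo sapiens) for cytotoxicity (a lower number here means that less compound is tolerated, a higher number that more compound is tolerated), namely > 50000 nM. Compound 2 `O=C(NC(=S)N1CCc2c(OCCCCCOc3ccc(Cl)cc3)cccc21)c1cccc([N+](=O)[O-])c1` gives 12100 nM, the only number shown in this assay. For the measured compounds named here, the one measured step, an at least 4.1-fold lower number from compound 1 to compound 2 (0.61 log units; beyond the scatter), concerns the limit of > 50000 nM in this assay, at which 1 of the 2 values shown sits, and exchanges the whole acyl arm, so it bears only loosely on the smaller change to compound 3 `N#Cc1cccc(C(=O)NC(=S)N2CCc3c(OCCCCCOc4ccc(Cl)cc4)cccc32)c1`, namely (cyano in place of nitro on an aromatic carbon). Going by the values given here, no step isolating the nitro group exists; the expected step of a 1.2-fold higher number from compound 2 to compound 3 (0.09 log units; within the scatter) is therefore none beyond the scatter. Compound 3 is estimated at 15000 nM, within 6000 nM to 40000 nM.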

Compound 3, half-maximal cytotoxic concentration: 9750 nM
Compound 3: the middle estimate sits 1.5-fold (0.19 log units) above what was measured; the range from low to high includes it.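

In this assay, exchanging the group on this aromatic carbon gives a 1.2-fold lower number from compound 2 to compound 3 (0.09 log units; within the scatter), so nitro and cyano cannot be told apart here and the value of compound 2 does not depend on nitro specifically. The 3-cyanophenyl arm in place of phenoxy gives an at least 5.1-fold lower number from compound 1 to compound 3 (0.70 log units; beyond the scatter), the same direction as seen with the 3-nitrophenyl arm. Compound 1 stands at a limit, which is not a number: the limit of > 50000 nM in this assay, at which 1 of the 3 values shown sits.

Open, as far as these compounds go, is whether an amine or a carboxylic acid on this carbon would read the same. Also open, from the compounds shown here alone, is whether an unsubstituted phenyl arm would keep the lower number.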